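Thiophen-2-yl to 1H-indol-7-yl: cytotoxicity working notes

The compounds below may be only part of what the source reports. "The series", "measured", "known", "first", "only" and "open" are said of these compounds alone.

Measured so far in a toxicity assay on MT4 cells (Homo sapiens) for cytotoxicity, read by MTT assay, with a stated time of 5 days; a higher number here means that more compound is tolerated, a lower number that less compound is tolerated:
compound 1 (`Cc1cnc(Nc2ccc(C#N)cc2)nc1Nc1c(F)cc(-c2cncnc2)cc1F`) gives 900 nM here
compound 2 (`Cc1cc(-c2cccs2)cc(C)c1Nc1ccnc(Nc2ccc(C#N)cc2)n1`) gives 10000 nM here

Compound 2 holds the higher of the two numbers, and its gap to compound 1 lies beyond the scatter. Compound 3 (`Cc1cc(-c2cccc3cc[nH]c23)cc(C)c1Nc1ccnc(Nc2ccc(C#N)cc2)n1`) carries 1H-indol-7-yl in place of thiophen-2-yl on an aromatic carbon. Among the compounds with values here, no measured pair differs in one place only, so no direct precedent for this change exists. In this assay a small fall is expected, not clearly beyond the scatter. The lean downward rests only on compound 2 at 10000 nM being the top number, while compound 1 at 900 nM shows that lower numbers occur. The expected change is a 1.7-fold lower number from compound 2 to compound 3 (0.22 log units; within the scatter) as estimated here. For compound 3 the estimated value is 6000 nM with an expected range from 2000 nM to 18000 nM in this assay.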

Compound 3, half-maximal cytotoxic concentration: 1000 nM
Compound 3: middle estimate off by 6.0-fold (0.78 log units), on the high side; the whole stated range lies above it.
By their numbers in this assay, from the lowest: compounds 1 and 3 (each within the scatter of the next); then compound 2.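

In this assay the group on this aromatic carbon, para to a large group and meta to two methyl groups, clearly matters: 1H-indol-7-yl in place of thiophen-2-yl gives a 10-fold lower number from compound 2 to compound 3 (1.00 log units; beyond the scatter). Within the data shown here, this is the first single-place change, and it shows that less compound is tolerated with 1H-indol-7-yl at this position than with thiophen-2-yl. No measurement at hand explains the step.

With only these two groups at this carbon, the added six-membered aromatic ring and the hydrogen-bond donor of 1H-indol-7-yl cannot be told apart as sources of the change. As far as these compounds go, how a morpholine or a carboxylic acid on the same carbon would stand in this assay remains open.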